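This account rests on a few compounds, and the source may have more. Where it says the series, first, only, none or still open, it means among the compounds named here.

Measured so far in a functional assay on BMDM cells (Mus musculus, strain C57BL/6) for inhibition, with a stated time of 2 days; a lower number here means a stronger inhibitor, a higher number a weaker inhibitor:
compound 1, `Cc1cc(NC(=O)Cn2cc(-c3ccc(Cl)cc3)nn2)no1`, gives 1910 nM
compound 2, `Cc1csc(NC(=O)Cn2cc(-c3ccccc3Cl)nn2)n1`, gives 1240 nM
compound 3, `Cc1csc(NC(=O)Cn2cc(-c3cccc(N)c3)nn2)n1`, gives 250 nM

Compound 3 carries the lowest number of the three: compound 2 sits at 1240 nM and compound 1 at 1910 nM, both beyond the scatter from it. Compound 4, `Cc1csc(NC(=O)Cn2cc(-c3ccc(Cl)cc3)nn2)n1`, is not yet measured. It differs from compound 3 as follows: 4-chlorophenyl in place of 3-aminophenyl on an aromatic carbon. Going by the values given here, the one step that bears on the change is a 5.0-fold lower number from compound 2 to compound 3 (0.70 log units; beyond the scatter), which ran in the opposite direction of the present change. Compound 1 also carries the 4-chlorophenyl, on a different core, and its value is well above that of compound 3. A weaker compound is therefore expected, with a 5.6-fold higher number from compound 3 to compound 4 (0.75 log units; beyond the scatter). Compound 4 is estimated at 1400 nM, range 600 nM to 3200 nM.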

Compound 4, half-maximal inhibitory concentration: 520 nM
Compound 4: middle estimate off by 2.7-fold (0.43 log units), on the high side; measured number below the stated range.
By their numbers in this assay, from the lowest: compound 3; then compound 4; then compounds 2 and 1 (each within the scatter of the next).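

At this aromatic carbon in this assay the 4-chlorophenyl trails the 3-aminophenyl, with a 2.1-fold higher number from compound 3 to compound 4 (0.32 log units; beyond the scatter) and yet beats the 2-chlorophenyl, with a 2.4-fold lower number from compound 2 to compound 4 (0.38 log units; beyond the scatter) so the place of the chlorine on the phenyl ring matters and not only the change from amine to chlorine. With the 4-chlorophenyl held constant, the core can now be read on its own, with a 3.7-fold lower number from compound 1 to compound 4 (0.57 log units; beyond the scatter) and the 4-methyl-1,3-thiazol-2-yl is favoured over the 5-methyl-1,2-oxazol-3-yl. No measured evidence accounts for these differences.

Still open, as far as these compounds go, is whether the lower number of compound 3 follows from the amine itself or from its place on the phenyl ring. A 4-aminophenyl or a 3-chlorophenyl on the shared core would separate the two.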